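From allyl to cyclopropyl: an expected cytotoxicity

The source may report more compounds than this note shows. Statements on the series, on what has been measured and on what is new or still open speak of the compounds shown alone.

In an ADME assay on PBMC cells (Homo sapiens) for cytotoxicity, with a stated time of 5 days (on this read-out lower numbers stand for stronger inhibition and higher numbers for weaker inhibition), compound 1 (`C=CCNc1ncnc2c1ncn2[C@H]1C[C@H](N=[N+]=[N-])[C@@H](CO)O1`) gives 51100 nM as a measured number. Compound 2 (`C=CCNc1nc(N)nc2c1ncn2[C@H]1C[C@H](N=[N+]=[N-])[C@@H](CO)O1`) gives > 100000 nM as a limit and not a number. Compound 3 (`COc1nc(OC)c2ncn([C@H]3C[C@H](N=[N+]=[N-])[C@@H](CO)O3)c2n1`) gives > 100000 nM as a limit too. Compound 2 therefore stands at the limit of > 100000 nM in this assay, at which 2 of the 3 values shown sit, and has no exact value. Compound 4 (`[N-]=[N+]=N[C@H]1C[C@H](n2cnc3c(NC4CC4)nc(N)nc32)O[C@@H]1CO`) differs from it by cyclopropyl in place of allyl on a nitrogen on an aromatic ring with cyclopropyl in place of allyl on a nitrogen on an aromatic ring. Among the compounds with values here, the only measured step runs an at least 1.9-fold higher number from compound 1 to compound 2 (0.29 log units; that floor lies within the scatter) and concerns a different change, so no measured step covers this swap. The expected change is a number no higher from compound 2 to compound 4 (the limit leaves the size open) in this assay with no shift beyond the scatter in either direction. Compound 4 is estimated at 100000 nM with an expected range from 40000 nM to 250000 nM in this measurement.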

Compound 4, half-maximal inhibitory concentration: > 100000 nM
Compound 4: a limit, no number (the forecaster's own chance of this, stated with the estimate: 65%); the middle value lies on the limit itself.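

Compound 2 and compound 4 each give a limit, not a number, so no step can be read between them. Left open is whether cyclopropyl in place of allyl changes cytotoxicity at all.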